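A Chloropyridine Swap on the Amide Carbonyl

The source may hold more compounds than are shown below. What is called first, only, known or untested is meant among the compounds shown, and "the series" means these compounds.

Of the compounds shown here, two have numbers so far in a functional assay on A-375 cells (Homo sapiens) for antiproliferative activity, read by MTT assay, with a stated time of 48 h; a lower number here means a stronger inhibitor, a higher number a weaker inhibitor. Compound 1 `O=C(Nc1cc(-c2ccccc2)[nH]n1)c1ccc(Cl)nc1` gives 7850 nM, and compound 2 `O=C(Nc1cc(-c2ccc(Br)cc2)[nH]n1)c1cccnc1Cl` gives 8220 nM, which places the two within the scatter of each other.

Compound 3 `O=C(Nc1cc(-c2ccc(Br)cc2)[nH]n1)c1ccc(Cl)nc1` has yet to be measured. It has the same atoms as compound 2, joined differently: 6-chloropyridin-3-yl in place of 2-chloropyridin-3-yl on a carbonyl carbon. In words, 6-chloropyridin-3-yl stands in place of 2-chloropyridin-3-yl on a carbonyl carbon.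

Among the compounds with values here, no measured pair shows this change on its own, so the data offer no direct guide to its size or direction. With only compound 1 at 7850 nM and compound 2 at 8220 nM to go on, no step beyond the scatter is expected in this assay. The estimate corresponds to a 1.1-fold lower number from compound 2 to compound 3 (0.04 log units; within the scatter), an expected change within the scatter. Compound 3 is expected at 7500 nM, with an estimated range of 3500 nM to 16000 nM.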

Compound 3, half-maximal inhibitory concentration: 8890 nM
The estimate for compound 3 lay 1.2-fold (0.07 log units) below the measured number, within the range that was stated.
By their numbers in this assay, from the lowest: compounds 1, 2 and 3 (each within the scatter of the next).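

In this assay, within the data shown here, 6-chloropyridin-3-yl in place of 2-chloropyridin-3-yl on the carbonyl carbon gives a 1.1-fold higher number from compound 2 to compound 3 (0.03 log units; within the scatter), the first direct reading of this change, and it shows that the two chloropyridine isomers cannot be told apart in this assay. Compound 3 also supplies the first reading for bromo in place of hydrogen on an aromatic carbon, with a 1.1-fold higher number from compound 1 to compound 3 (0.05 log units; within the scatter), so neither single change shown here moves the number beyond the scatter. No measured evidence is available to explain these readings.

Still open, going by these compounds, is whether an amine or a methoxy group in place of the chloro on the pyridine would produce a step beyond the scatter. On these data alone, it is equally open whether a carboxylic acid or a longer chain in place of the bromo would do so.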